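Swapping an isopropyl for an oxan-2-yl on a pyrazole nitrogen

The compounds below may be only part of what the source reports. "The series", "measured", "known", "first", "only" and "open" are said of these compounds alone.

Measured so far:
Compound 1, `Cc1ccc(C(=O)Nc2cccc(C(F)(F)F)c2)cc1-c1ccc2c(-c3cn[nH]c3)n[nH]c2c1`: 55.6 nM
Compound 2, `CCCn1cc(-c2n[nH]c3cc(-c4cc(C(=O)Nc5cccc(C(F)(F)F)c5)ccc4C)ccc23)cn1`: 3.2 nM
Compound 3, `Cc1ccc(C(=O)Nc2cccc(C(F)(F)F)c2)cc1-c1ccc2c(-c3cnn(C(C)C)c3)n[nH]c2c1`: 7.7 nM

All three numbers come from an assay on isolated protein for inhibition of Discoidin domain-containing receptor 2 (Homo sapiens), read by ELISA, with a stated time of 60 min; on this read-out higher numbers stand for weaker inhibition and lower numbers for stronger inhibition. Compound 3 stands second highest of the three: the step of a 2.4-fold higher number from compound 2 to compound 3 (0.38 log units; beyond the scatter) places it close to compound 2, while the step of a 7.2-fold lower number from compound 1 to compound 3 (0.86 log units; beyond the scatter) sets it well apart from compound 1.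

Compound 4, `Cc1ccc(C(=O)Nc2cccc(C(F)(F)F)c2)cc1-c1ccc2c(-c3cnn(C4CCCCO4)c3)n[nH]c2c1`, has not been measured. It differs from compound 3 by oxan-2-yl in place of isopropyl on an aromatic nitrogen.

For the measured compounds named here, two measured steps bear on this position. Replacing the hydrogen on that nitrogen gave a 17-fold lower number from compound 1 to compound 2 (1.24 log units; beyond the scatter) and a 7.2-fold lower number from compound 1 to compound 3 (0.86 log units; beyond the scatter), so carrying a group there matters a great deal. Between two such groups, however, the difference was only a 2.4-fold higher number from compound 2 to compound 3 (0.38 log units; beyond the scatter). Going by the values given here, no measured step involves a ring or an oxygen at this place, so the oxan-2-yl remains untested ground. The expectation for compound 4 is therefore a modest step, a 1.3-fold higher number from compound 3 to compound 4 (0.11 log units; within the scatter), likely within or just beyond the scatter. Compound 4 is estimated at 10 nM, with a plausible range of 4 nM to 30 nM.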

Compound 4, half-maximal inhibitory concentration: 5.2 nM
Compound 4: middle estimate off by 1.9-fold (0.28 log units), on the high side; measured number inside the range.
By their numbers in this assay, from the lowest: compounds 2, 4 and 3 (each within the scatter of the next, the first and the last beyond it); then compound 1.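

The oxan-2-yl puts a six-membered ring and a hydrogen-bond acceptor on the aromatic nitrogen where isopropyl had neither, yet the change is only a 1.5-fold lower number from compound 3 to compound 4 (0.17 log units; within the scatter), and the comparison with propyl is a 1.6-fold higher number from compound 2 to compound 4 (0.21 log units; within the scatter). The gain over the bare nitrogen survives this change, at an 11-fold lower number from compound 1 to compound 4 (1.03 log units; beyond the scatter), so this position accepts a ring as well as an open chain, and having a group there counts for more than which of these groups it is, although compound 2 and compound 3 still differ beyond the scatter. No measurement at hand offers a reason for these results.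

Cyclohexyl, the same ring without its oxygen, would be needed to separate the effect of the ring from that of the oxygen. Going by these compounds, how an amine or a carboxylic acid at the end of a longer chain on this nitrogen would fare also remains open.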